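Methyl-to-fluoro swap on two inactive benzoxazinone sulfonamides

The source may report more compounds than this note shows. Statements on the series, on what has been measured and on what is new or still open speak of the compounds shown alone.

Three compounds were tested in a functional assay on HepG2 cells (Homo sapiens) for antiproliferative activity, read by MTT assay, with a stated time of 72 h; on this read-out higher numbers stand for weaker inhibition and lower numbers for stronger inhibition. Compound 1 `O=C1COc2ccc(-c3cnc(Cl)c(NS(=O)(=O)c4ccc(F)cc4)c3)cc2N1c1ccc(F)cc1` reaches only the limit of the assay, > 40000 nM. Compound 2 `Cc1ccc(N2C(=O)COc3ccc(-c4cnc(Cl)c(NS(=O)(=O)c5ccc(F)cc5)c4)cc32)cc1` gives 39600 nM in this assay. The change from compound 2 to compound 1 is fluoro in place of methyl on an aromatic carbon and it made a step of a number no lower from compound 2 to compound 1 (the limit leaves the size open), a size that cannot be read because of the limit of > 40000 nM in this assay, at which 2 of the 3 values shown sit. Compound 3 `Cc1ccc(N2C(=O)COc3ccc(-c4cccc(NS(=O)(=O)c5ccc(F)cc5)c4)cc32)cc1` likewise returns only the limit, > 40000 nM. How the core of compound 3 differs from that of compound 2 is not broken down here. Compound 4 `O=C1COc2ccc(-c3cccc(NS(=O)(=O)c4ccc(F)cc4)c3)cc2N1c1ccc(F)cc1` differs from compound 3 by fluoro in place of methyl on an aromatic carbon, the same change as in the measured pair. Compound 4 is expected to stay at the limit, with a step that the limit leaves unreadable from compound 3 to compound 4 estimated, because compound 3 already sits at > 40000 nM and the measured pair gave a number no lower from compound 2 to compound 1 (the limit leaves the size open). The estimate for compound 4 is 50000 nM, between 20000 nM and 150000 nM.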

Compound 4, half-maximal inhibitory concentration: > 40000 nM
Compound 4 was reported as a limit; the forecaster's own chance of this, stated with the estimate: 80%; the middle value lies beyond the limit too.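

No step can be read from compound 3 to compound 4, since each of them returns only a limit: the limit of > 40000 nM in this assay, at which 3 of the 4 values shown sit. The compounds shown leave open how far 4-methylphenyl to 4-fluorophenyl shifts activity in this assay.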